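The source may hold more compounds than are shown below. What is called first, only, known or untested is meant among the compounds shown, and "the series" means these compounds.

Measured so far:
compound 1 `Nc1cc(N)c2nc(-c3ccccc3)c(Sc3ccc(F)cc3)nc2c1` — 72400 nM
compound 2 `Nc1cc(N)c2nc(-c3ccccc3)c(NCc3ccc(F)cc3)nc2c1` — 21900 nM

Among the measured compounds shown here, in a functional assay on OVCAR-8 cells (Homo sapiens) for inhibition, read by sulforhodamine B assay, with a stated time of 48 h (a lower number here means that less compound is tolerated, a higher number that more compound is tolerated), compound 2 gives 21900 nM, the lowest of the two numbers so far; its nearest neighbour is compound 1 with 72400 nM, and the single measured step is a 3.3-fold lower number from compound 1 to compound 2 (0.52 log units; beyond the scatter).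

Compound 3 `COc1ccc(Sc2nc3cc(N)cc(N)c3nc2-c2ccccc2)cc1` is not yet measured. Its change from compound 2 is (4-methoxyphenyl)sulfanyl in place of (4-fluorobenzyl)amino on an aromatic carbon. This largely retraces the measured step in reverse: the (4-fluorobenzyl)amino group that entered between compound 1 and compound 2 leaves again, and an arylsulfanyl group returns, now carrying a methoxy group where compound 1 carried fluorine. For the measured compounds named here, the one step that bears on this, a 3.3-fold lower number from compound 1 to compound 2 (0.52 log units; beyond the scatter), was modest but beyond the scatter. Reversing the linker change should therefore move the number back upward, toward compound 1; the swap of fluorine for methoxy on the outer ring has no measured counterpart here, so its contribution is unknown and widens the range.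

For compound 3 the expected value is 55000 nM (range 20000 nM to 150000 nM), an expected step of a 2.5-fold higher number from compound 2 to compound 3 (0.40 log units; beyond the scatter).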

Compound 3, concentration lethal to 50% of the cells: < 100000 nM
Compound 3: a limit, no number (the forecaster's own chance of this, stated with the estimate: 10%); the middle value lies beyond the limit too.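

In this assay compound 3 gives < 100000 nM, a limit and not a number, so its steps from compound 1 and compound 2 cannot be read. The compounds shown leave open where compound 3 stands against both, and whether methoxy in place of fluoro on the arylsulfanyl series changes the number at all.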